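Solubility notes: replacing the 4-cyanophenyl arm

This account rests on a few compounds, and the source may have more. Where it says the series, first, only, none or still open, it means among the compounds named here.

Measured compounds:
compound 1, `COc1ccc(F)cc1CNCCCNc1ccnc2cc(Cc3ccc(C#N)cc3)ccc12`, 4200 nM
compound 2, `CC(C)(C)c1ccc(Oc2ccc3c(NCCCNCc4ccco4)ccnc3c2)cc1`, 14500 nM
compound 3, `COc1cccc(CNCCCNc2ccnc3cc(Cc4ccc(C#N)cc4)ccc23)c1O`, 4200 nM

All three values come from a physicochemical assay for solubility, with a stated time of 18 h, at pH 7.4; on this read-out higher numbers stand for higher solubility and lower numbers for lower solubility. Compound 1 sits level with compound 3 and, together with it, at the bottom of the three numbers; compound 2 stands a clear step higher, but compound 2 differs from compound 1 in several places at once, so its value shows only where a distant analogue lands. Among the compounds with values here, the single one-place step that is measured, no change at the digits printed from compound 1 to compound 3 (within the scatter), concerns the other end of the molecule and lies within the scatter.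

Compound 4, `COc1ccc(F)cc1CNCCCNc1ccnc2cc(Cc3cc(C)cc(C)c3)ccc12`, is not yet measured. Its difference from compound 1 is 3,5-dimethylphenyl in place of 4-cyanophenyl on a saturated chain carbon bound to an aromatic carbon; the 4-cyanophenyl with its 1 triple bond outside aromatic rings and 1 hydrogen-bond acceptor leaves, and 3,5-dimethylphenyl with 0 hydrogen-bond acceptors enters. Within the data shown here, no measured step touches this position, so no precedent of a given size exists. Compound 4 is therefore expected to give 2000 nM in this assay, within 700 nM to 6000 nM, an estimated step of a 2.1-fold lower number from compound 1 to compound 4 (0.32 log units; beyond the scatter) that may or may not clear the scatter.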

Compound 4, solubility: 4200 nM
The estimate for compound 4 lay 2.1-fold (0.32 log units) below the measured number; measured number inside the range.
By their numbers in this assay, from the lowest: compounds 1, 3 and 4 (each within the scatter of the next); then compound 2.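

In this assay, within the data shown here, the first measured step at this position reads no change at the digits printed from compound 1 to compound 4 (within the scatter), so on the core of compound 1, 3,5-dimethylphenyl can stand in place of 4-cyanophenyl on a saturated chain carbon bound to an aromatic carbon without a step that can be read. The exchange removes the nitrile, with its triple bond and its hydrogen-bond acceptor, and keeps the count of 8 heavy atoms and the six-membered aromatic ring of carbon only; in this one pair, neither the nitrile nor the acceptor is needed to hold the number where compound 1 stands. The earlier compounds shown here could not show this: compounds 1 and 3 both carry 4-cyanophenyl, and compound 2 differs from compound 1 in several places at once. No supporting measurement is available to explain this result.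

Open, as far as these compounds go, is whether an arm carrying a carboxylic acid or a dimethylamino group, rather than these two neutral aryl groups, would move the number beyond the scatter. Also open, from the compounds shown here alone, are a longer chain in place of the single saturated carbon and whether the 3,5-dimethylphenyl exchange reads the same alongside the 2-hydroxy-3-methoxyphenyl group of compound 3.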